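Moving the Chlorine from 2-Chlorophenyl to 4-Chlorophenyl

A few compounds are considered here, and "the series" means these few. Any claim that something is new, unique, unknown or untested is made for them only; others in the source may bear on it.

Going by the values given here, in a functional assay on MCF7 cells (Homo sapiens) for cytotoxicity, read by MTT assay, with a stated time of 72 h (a lower number here means a stronger inhibitor, a higher number a weaker inhibitor), compound 2 `COc1ccc(/C=C2\CCC/C(=C\c3ccccc3Cl)C2=O)cc1OC` gives 10400 nM, the only exact number so far. The reading for compound 1 `COc1cccc(/C=C2\CCC/C(=C\c3ccc(O)cc3)C2=O)c1OC` is a limit, > 20000 nM. Compound 3 `COc1ccc(/C=C2\CCC/C(=C\c3ccc(Cl)cc3)C2=O)cc1OC` carries 4-chlorophenyl in place of 2-chlorophenyl on a double-bonded chain carbon bound to a double-bonded ring carbon, (4-chlorophenyl in place of 2-chlorophenyl on a double-bonded chain carbon bound to a double-bonded ring carbon). Among the compounds with values here, no measured pair shows what such a change does, so no shift in either direction beyond the scatter is expected in this assay. The estimated 1.2-fold lower number from compound 2 to compound 3 (0.06 log units; within the scatter) is therefore small. For compound 3 the expected value is 9000 nM, with an estimated range from 3500 nM to 20000 nM.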

Compound 3, half-maximal inhibitory concentration: 6300 nM
For compound 3 the middle estimate is 1.4-fold (0.15 log units) above the measured one; the measured number falls inside the stated range.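

In this assay, 4-chlorophenyl in place of 2-chlorophenyl on a double-bonded chain carbon bound to a double-bonded ring carbon gives a 1.7-fold lower number from compound 2 to compound 3 (0.22 log units; within the scatter). Going by these compounds alone, this is the first measured step at this place, and it shows that these two placements of the chlorine cannot be told apart in this reading. Nothing measured here bears on the cause of this step. On these data alone, whether the chlorine itself matters remains open, as does what an amine or a carboxylic acid would do at this place.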